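Aryl variation on the pyridone core: 2-nitrophenyl analogue

This account rests on a few compounds, and the source may have more. Where it says the series, first, only, none or still open, it means among the compounds named here.

Measured compounds in a functional assay for inhibition, tested at 100 ug/mL; a lower number here means a weaker effect, a higher number a stronger effect of the compound at the concentration tested:
compound 1 `Cc1cc(O)c(C(C)C)cc1-c1cc(-c2cccs2)c(C#N)c(=O)[nH]1`, 68%
compound 2 `Cc1cc(O)c(C(C)C)cc1-c1cc(-c2ccco2)c(C#N)c(=O)[nH]1`, 70%
compound 3 `Cc1cc(O)c(C(C)C)cc1-c1cc(-c2ccc(N(C)C)cc2)c(C#N)c(=O)[nH]1`, 68%

Compound 1 stands level with compound 3 at the digits shown, the two together the lowest of the three numbers; compound 2 lies nearest above it, a number 2 percentage points higher from compound 1 to compound 2 (within the scatter). All three aryl groups on the shared core give readings within the scatter of one another: no change at the digits printed from compound 1 to compound 3 (within the scatter) and a number 2 percentage points lower from compound 2 to compound 3 (within the scatter).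

Compound 4 `Cc1cc(O)c(C(C)C)cc1-c1cc(-c2ccccc2[N+](=O)[O-])c(C#N)c(=O)[nH]1` differs from compound 1 by 2-nitrophenyl in place of thiophen-2-yl on an aromatic carbon. The measured steps bear on it only loosely, since none of them involves 2-nitrophenyl; yet each exchange of the aryl group so far left the read-out unchanged beyond the scatter. No step beyond the scatter is therefore expected here either: the estimated step is a number 1 percentage points lower from compound 1 to compound 4 (within the scatter). Compound 4 is expected to give about 67% in this assay, within 54% to 80%.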

Compound 4, a percentage reported as inhibition, at one concentration (the size of the read-out at that concentration, not a potency): 37.5%
Estimate against measurement, compound 4: 29.5 percentage points above; the measured number lies below the stated range.
By their numbers in this assay, from the lowest: compound 4; then compounds 1, 3 and 2 (each within the scatter of the next).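

At this position, opposite the ring nitrogen, the read-out in this assay does depend on the aryl group. With 2-nitrophenyl the shift is a number 30.5 percentage points lower from compound 1 to compound 4 (beyond the scatter) and also a number 30.5 percentage points lower from compound 3 to compound 4 (beyond the scatter) and a number 32.5 percentage points lower from compound 2 to compound 4 (beyond the scatter), whereas thiophen-2-yl, furan-2-yl and 4-(dimethylamino)phenyl remain within the scatter of one another. No measurement on hand accounts for this step. Still open, on these data alone, is whether the nitro group itself or its place on the phenyl ring matters. Unsubstituted phenyl and 4-nitrophenyl on the shared core would separate these two readings.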